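The source may report more compounds than this note shows. Statements on the series, on what has been measured and on what is new or still open speak of the compounds shown alone.

Values in a functional assay on PANC-1 cells (Homo sapiens) for inhibition, read by MTT assay, with a stated time of 24 h; a higher number here means a weaker inhibitor, a lower number a stronger inhibitor:
- compound 1 `CC1(C)[C@H]2CC[C@]1(C)N(Cc1cn(-c3cccc(C#N)c3)nn1)C(=O)C2`: 260 nM
- compound 2 `CC1(C)[C@H]2CC[C@]1(C)N(Cc1cn(-c3cccc(O)c3)nn1)C(=O)C2`: 280 nM

Within the data shown here, compound 2 stands level with compound 1, the only other measured compound, as the two numbers lie within the scatter of each other. The next compound, compound 3 `COc1cccc(-n2cc(CN3C(=O)C[C@@H]4CC[C@@]3(C)C4(C)C)nn2)c1`, has methyl in place of hydrogen on an oxygen on an aromatic ring, so 3-hydroxyphenyl becomes 3-methoxyphenyl (methyl in place of hydrogen on an oxygen on an aromatic ring). Among the measured compounds shown here, only one measured step bears on this, and it is a different change at the same group: hydroxy in place of cyano on an aromatic carbon, a 1.1-fold higher number from compound 1 to compound 2 (0.03 log units; within the scatter). That single step is thin evidence, yet it gives no sign of sensitivity to this swap, so no step beyond the scatter is expected in this assay. The estimated step is no change at the digits printed from compound 2 to compound 3 (within the scatter). Compound 3 is expected at about 280 nM, with an estimated range from 120 nM to 650 nM.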

Compound 3, half-maximal inhibitory concentration: 860 nM
Beside the measured number, compound 3's estimate is 3.1-fold (0.49 log units) below it; measured number outside the range, above it.
By their numbers in this assay, from the lowest: compounds 1 and 2 (each within the scatter of the next); then compound 3.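

In this assay this place on the ring turns out to be sensitive: putting methyl on the oxygen of 3-hydroxyphenyl gives a 3.1-fold higher number from compound 2 to compound 3 (0.49 log units; beyond the scatter) and methoxy in place of the nitrile gives a 3.3-fold higher number from compound 1 to compound 3 (0.52 log units; beyond the scatter) in the same direction. Among these compounds, the nitrile and hydroxy compounds had stood level, so the group here could have seemed freely exchangeable, but methoxy is the first to separate from the others, towards a weaker inhibitor. Nothing measured here explains why one added methyl changes the number.

Still open, on these data alone, is whether a longer chain on the same oxygen, such as ethoxy, moves the number further. As far as these compounds go, it is also open how an amine or a carboxylic acid in this place would compare with hydroxy and the nitrile.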